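From tetrahydroisoquinoline to hydroxypiperidine: a step without precedent

A few compounds are considered here, and "the series" means these few. Any claim that something is new, unique, unknown or untested is made for them only; others in the source may bear on it.

Measured in a functional assay on HCT-116 cells (Homo sapiens) for cytotoxicity, read by MTT assay, with a stated time of 72 h; a higher number here means a weaker inhibitor, a lower number a stronger inhibitor:
Compound 1 `O=S(=O)(c1ccccc1)c1nc2ccccc2nc1N1CCc2ccccc2C1`: 18700 nM
Compound 2 `COc1ccc(S(=O)(=O)c2nc3ccccc3nc2N2CCc3ccccc3C2)cc1`: 22100 nM
Compound 3 `O=S(=O)(c1ccc(Br)cc1)c1nc2ccccc2nc1N1CCc2ccccc2C1`: > 50000 nM, a limit of the assay

Only compound 1 and compound 2 give actual numbers, and these two stand level, with a 1.2-fold higher number from compound 1 to compound 2 (0.07 log units; within the scatter). Compound 3 gives only a limit, as recorded in the limit of > 50000 nM in this assay, at which 1 of the 3 values shown sits.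

Compound 4 `COc1ccc(S(=O)(=O)c2nc3ccccc3nc2N2CCCC(O)C2)cc1` keeps the methoxy of compound 2 but carries 3-hydroxypiperidin-1-yl in place of 1,2,3,4-tetrahydroisoquinolin-2-yl on an aromatic carbon. Among the measured compounds shown here, no measured step touches this place, since all three exchange hydrogen, methoxy or bromo elsewhere while 1,2,3,4-tetrahydroisoquinolin-2-yl stays. They therefore bear on it only indirectly. The two steps beyond the scatter, an at least 2.6-fold higher number from compound 1 to compound 3 (0.42 log units; beyond the scatter) and an at least 2.2-fold higher number from compound 2 to compound 3 (0.35 log units; beyond the scatter), both lead towards the limit, and they are at least modest. On that thin basis, a modest move to a higher number in this assay is expected, and a result reported only as a limit would be no surprise. The expected step is a 1.4-fold higher number from compound 2 to compound 4 (0.13 log units; within the scatter). For compound 4 the estimated value is 30000 nM, with an expected range from 12000 nM to 70000 nM.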

Compound 4, half-maximal inhibitory concentration: 3520 nM
The estimate for compound 4 lay 8.5-fold (0.93 log units) above the measured number, outside the stated range (below it).
By their numbers in this assay, from the lowest: compound 4; then compounds 1 and 2 (each within the scatter of the next). At a limit, above all of these: compound 3.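

The exchange of 1,2,3,4-tetrahydroisoquinolin-2-yl for 3-hydroxypiperidin-1-yl, with the methoxy held constant, gives in this assay a 6.3-fold lower number from compound 2 to compound 4 (0.80 log units; beyond the scatter). The earlier compounds varied only hydrogen, methoxy or bromo elsewhere, and their only steps beyond the scatter led towards the limit of compound 3, so this is the first step shown that goes beyond the scatter towards a stronger inhibitor, and it shows that the place next to the ring nitrogen can move the number in that direction. The entering group lacks the six-membered aromatic ring of carbon only and brings a hydrogen-bond donor, but this single step does not separate those differences, and nothing measured here accounts for it.

On these data alone, it remains open whether the hydroxy group or the loss of the aromatic ring carries the step, a question on which plain piperidin-1-yl at this place would bear. Also open, as far as these compounds go, are whether the step holds with hydrogen or bromo in place of the methoxy, since 3-hydroxypiperidin-1-yl appears here only with methoxy, and how a piperazine or an open-chain amine such as dimethylamino would read in this assay.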